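Chain-end phenyl on the ether of compound 1

The source may hold more compounds than are shown below. What is called first, only, known or untested is meant among the compounds shown, and "the series" means these compounds.

Among the measured compounds shown here, compound 1 `CCCCOc1ccc2c(Cl)ccnc2c1` carries the highest number among the three measured members. In a functional assay on NCI-H1650 cells (Homo sapiens) for cytotoxicity, read by MTT assay, with a stated time of 48 h (on this read-out higher numbers stand for weaker inhibition and lower numbers for stronger inhibition), compound 1 gives 2570 nM, whereas compound 2 `C=CCOc1ccc2c(NCCN(C)C)ccnc2c1` gives 930 nM and compound 3 `CN(C)CCCNc1ccnc2cc(OCc3ccc(F)cc3)ccc12` gives 940 nM; both sit beyond the scatter below compound 1, though each differs from it in more than one place, so no single change is attributable.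

Compound 4 `Clc1ccnc2cc(OCCc3ccccc3)ccc12` differs from compound 1 only by phenyl in place of ethyl on a saturated chain carbon, two bonds along the chain from an oxygen on an aromatic ring. For the measured compounds named here, no measured pair isolates this change. A modest step toward a lower number, at the edge of the scatter, is the expectation for the step of a 1.4-fold lower number from compound 1 to compound 4 (0.15 log units; within the scatter). For compound 4 in this assay the estimate is 1800 nM, with a range from 600 nM to 5000 nM.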

Compound 4, half-maximal inhibitory concentration: 2300 nM
Estimate against measurement, compound 4: 1.3-fold (0.11 log units) below; low and high end bracket the measured number.
By their numbers in this assay, from the lowest: compounds 2 and 3 (each within the scatter of the next); then compounds 4 and 1 (each within the scatter of the next).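

On a saturated chain carbon, two bonds along the chain from an oxygen on an aromatic ring, phenyl in place of ethyl gives a 1.1-fold lower number from compound 1 to compound 4 (0.05 log units; within the scatter) in this assay. Among the compounds shown here, this pair is the first to isolate one change, and it shows that adding a six-membered aromatic ring at this place does not separate the two compounds on this read-out. No evidence on the cause bears on this result.

Still open, going by these compounds, is whether an amine or a carboxylic acid at the chain end, or a longer chain, would give a step beyond the scatter.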